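The source may hold more compounds than are shown below. What is called first, only, known or untested is meant among the compounds shown, and "the series" means these compounds.

Three related oximes have been tested for how strongly they harm cultured cells. Compound 2 `COc1ccc(/C=C/C(=N\O)c2ccc(OC)cc2)cc1` carries a methoxy group on both of its outer rings, and in an ADME assay on cells (Mus musculus, strain Balb/c) for cytotoxicity, read by MTT assay, with a stated time of 48 h (on this read-out lower numbers stand for higher toxicity in this test and higher numbers for lower toxicity in this test), compound 2 gives 2170000 nM. Compound 3 `COc1ccc(/C=C/C(=N\O)c2ccc(C)cc2)cc1` differs from compound 2 by methyl in place of methoxy on an aromatic carbon, and in this assay compound 3 gives 117000 nM, so the step amounts to a 19-fold lower number from compound 2 to compound 3 (1.27 log units; beyond the scatter). Compound 1 `COc1ccc(C(/C=C/c2ccc(F)cc2)=N/O)cc1` differs from compound 2 by fluoro in place of methoxy on an aromatic carbon, and in this assay compound 1 gives 13500 nM; here the step is a 160-fold lower number from compound 2 to compound 1 (2.21 log units; beyond the scatter), the largest movement among the three measured compounds.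

Compound 4 `Cc1ccc(C(/C=C/c2ccc(F)cc2)=N/O)cc1` has not yet been measured in this assay. It differs from compound 3 by fluoro in place of methoxy on an aromatic carbon, which is the same change that separates compound 1 from compound 2, made on the same kind of place. The cores of compound 3 and compound 2 differ only as described above: methyl in place of methoxy on an aromatic carbon. Because the earlier change produced a 160-fold lower number from compound 2 to compound 1 (2.21 log units; beyond the scatter), a lower number is expected for compound 4 as well, though the two changes need not add up fully when combined. The step from compound 3 to compound 4 is estimated at a 78-fold lower number from compound 3 to compound 4 (1.89 log units; beyond the scatter). For compound 4 the expected value in this assay is 1500 nM, with a likely range from 400 nM to 6000 nM.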

Compound 4, half-maximal cytotoxic concentration: 13200 nM
Compound 4: the middle estimate sits 8.8-fold (0.94 log units) below what was measured; measured number outside the range, above it.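

Among the compounds shown here, the change from methoxy to fluoro lowers the number on both cores in this assay, but its size does not carry over, and on the core of compound 3 it gives an 8.9-fold lower number from compound 3 to compound 4 (0.95 log units; beyond the scatter), much less than on the core of compound 2: the same change on two cores in this assay, a 160-fold lower number (2.21 log units; beyond the scatter) from compound 2 to compound 1 and an 8.9-fold lower number (0.95 log units; beyond the scatter) from compound 3 to compound 4, 18-fold (1.26 log units) apart, beyond the scatter of two such steps The change from methoxy to methyl also depends on its core, since it gives a clear step on the core of compound 2, whereas a 1.0-fold lower number from compound 1 to compound 4 (0.01 log units; within the scatter) lies within the scatter: the same change on two cores in this assay, a 19-fold lower number (1.27 log units; beyond the scatter) from compound 2 to compound 3 and a 1.0-fold lower number (0.01 log units; within the scatter) from compound 1 to compound 4, 18-fold (1.26 log units) apart, beyond the scatter of two such steps These four compounds therefore show that the two changes do not simply add up when combined, but they do not show why, and with only two cores for each change they give no rule for predicting the step on a further core.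

As far as these compounds go, it remains open whether swapping the methoxy group for a chloro group, an amine or a carboxylic acid would give a large step, a small one or none on these cores. From the compounds shown here alone, it is also open whether a longer group such as ethoxy would behave like methoxy, and whether the close agreement between compound 1 and compound 4 would hold for other groups.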